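The compounds below may be only part of what the source reports. "The series", "measured", "known", "first", "only" and "open" are said of these compounds alone.

Measured so far:
- compound 1 `Cc1cc(O)c(C(=O)/C=C/c2ccc(Cl)cc2)c(-c2ccccc2)c1C(=O)/C=C/c1ccc(Cl)cc1` — 7900 nM
- compound 2 `Cc1cc(O)c(C(=O)/C=C/c2ccccc2)c(-c2ccc(Br)cc2)c1C(=O)/C=C/c1ccccc1` — 8000 nM

In a functional assay on MDA-MB-231 cells (Homo sapiens) for cytotoxicity, read by MTT assay, with a stated time of 24 h (on this read-out lower numbers stand for stronger inhibition and higher numbers for weaker inhibition), compound 1 gives 7900 nM, the lower of the two numbers. Compound 2 gives 8000 nM in this assay; the gap between the two lies within the scatter, so the two stand level and no order between them is claimed.

Compound 3 `Cc1cc(O)c(C(=O)/C=C/c2ccc(Cl)cc2)c(-c2ccc(OCc3ccccc3)cc2)c1C(=O)/C=C/c1ccc(Cl)cc1` keeps the shared core of compound 1 and differs from it in one place: benzyloxy in place of hydrogen on an aromatic carbon. For the measured compounds named here, no measured pair shows a change of this kind, so the size of the step is not fixed by the data. The expected step from compound 1 is a 1.3-fold lower number from compound 1 to compound 3 (0.12 log units; within the scatter), a small shift in this assay that is expected to stay within or only just beyond the scatter. For compound 3 the estimate in this assay is 6000 nM, expected to fall between 2000 nM and 20000 nM.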

Compound 3, half-maximal inhibitory concentration: 30000 nM
Compound 3: the middle estimate sits 5.0-fold (0.70 log units) below what was measured; the measured number lies above the stated range.
By their numbers in this assay, from the lowest: compounds 1 and 2 (each within the scatter of the next); then compound 3.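

In this assay benzyloxy in place of hydrogen on an aromatic carbon, para to a large group, gives a 3.8-fold higher number from compound 1 to compound 3 (0.58 log units; beyond the scatter) and so moves the series toward weaker inhibition. For the compounds shown here, this is the first reading at this position, and it shows that the position is not indifferent to substitution, although the step is only modest in size. Nothing on hand accounts for the step.

With one substituent at this position, the contribution of the oxygen link cannot be separated from that of the added aromatic ring. On these data alone, whether methoxy, hydroxy or an amine at the same place would give a similar step stays open, as does whether the same change would give a similar step on another member of the series.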